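This account rests on a few compounds, and the source may have more. Where it says the series, first, only, none or still open, it means among the compounds named here.

Values in a functional assay on SGC-7901 cells (Homo sapiens) for antiproliferative activity, read by sulforhodamine B assay, with a stated time of 72 h; on this read-out lower numbers stand for stronger inhibition and higher numbers for weaker inhibition:
- compound 1 `N#Cc1ccc(NC(=S)N/N=C/c2ccc3ccccc3n2)cc1`: 23700 nM
- compound 2 `Cc1ccccc1NC(=S)N/N=C/c1ccc2ccccc2n1`: > 100000 nM (a limit)
- compound 3 `S=C(N/N=C/c1ccc2ccccc2n1)Nc1ccccc1Br`: > 100000 nM (a limit)

Compound 3 has no number, only a limit: it stands at the limit of > 100000 nM in this assay, at which 2 of the 3 values shown sit. The next structure is compound 4 `S=C(N/N=C/c1ccc2ccccc2n1)Nc1cccc(Cl)c1`, with 3-chlorophenyl in place of 2-bromophenyl on an amide-type nitrogen.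

Among the compounds with values here, the steps that bear on this change are those at the same nitrogen. The notes show an at least 4.2-fold higher number from compound 1 to compound 2 (0.62 log units; beyond the scatter). They also show an at least 4.2-fold higher number from compound 1 to compound 3 (0.62 log units; beyond the scatter). Both are beyond the scatter, and both are lower bounds on their size. The swap of bromo for methyl gives a step that the two limits leave unreadable from compound 2 to compound 3, so it adds no guidance. Within the data shown here, no measured compound carries 3-chlorophenyl, and in this assay only compound 1 gives a number, 23700 nM.

Compound 4 is therefore expected to stay weak, closer to the limit than to compound 1, and a second limit is quite possible. Any readable change is expected to be modest and towards a lower number, and the expected step is an at least 1.4-fold lower number from compound 3 to compound 4 (0.15 log units; that floor lies within the scatter). For compound 4 the estimated value is 70000 nM, with an expected range from 20000 nM to 150000 nM.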

Compound 4, half-maximal inhibitory concentration: 61300 nM
The estimate for compound 4 lay 1.1-fold (0.06 log units) above the measured number; low and high end bracket the measured number.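

In this assay, as far as these compounds go, the change from 2-bromophenyl to 3-chlorophenyl on the amide-type nitrogen gives an at least 1.6-fold lower number from compound 3 to compound 4 (0.21 log units; that floor lies within the scatter) as a step, and the change from 2-methylphenyl gives an at least 1.6-fold lower number from compound 2 to compound 4 (0.21 log units; that floor lies within the scatter) as a step, so both are floors whose true size stays unknown. 3-Chlorophenyl is the second group at this nitrogen to give a number rather than a limit, yet it falls short of 4-cyanophenyl, with a 2.6-fold higher number from compound 1 to compound 4 (0.41 log units; beyond the scatter) as the step. Compound 2 and compound 3 each carry a limit, not a number: the limit of > 100000 nM in this assay, at which 2 of the 4 values shown sit.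

Compound 3 and compound 4 differ in both the halogen and its place on the phenyl ring, so the two changes cannot be separated. From the compounds shown here alone, how an amine or a carboxylic acid on that phenyl ring would read remains open.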